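Chain change from compound 1 to compound 4

The source may report more compounds than this note shows. Statements on the series, on what has been measured and on what is new or still open speak of the compounds shown alone.

Values so far in a functional assay on the whole organism for inhibition, with Cavia porcellus as the target (a lower number here means that less compound is needed, a higher number that more compound is needed for the effect), are as follows.
- compound 1 `C=CCCn1c(=O)c2[nH]cnc2n(CCC)c1=O` gives 1.84 mg/kg
- compound 2 `CCCn1c(=O)n(CCOCC)c(=O)c2[nH]cnc21` gives 1.7 mg/kg
- compound 3 `CCCn1c(=O)n(CCCOC)c(=O)c2[nH]cnc21` gives 0.72 mg/kg

Compound 1 holds the highest of these three numbers, though compound 2 is not separated from it. Compound 4 `CCCn1c(=O)n(CCCCC(C)=O)c(=O)c2[nH]cnc21` differs from compound 1 by 2-acetylethyl in place of vinyl on a saturated chain carbon, two bonds along the chain from an aromatic nitrogen with 2-acetylethyl in place of vinyl on a saturated chain carbon, two bonds along the chain from an aromatic nitrogen. Two steps replace the same vinyl at this place: ethoxy gave a 1.1-fold lower number from compound 1 to compound 2 (0.03 log units; within the scatter) and methoxymethyl gave a 2.6-fold lower number from compound 1 to compound 3 (0.41 log units; beyond the scatter) in the same assay. Between those two replacements lies a 2.4-fold lower number from compound 2 to compound 3 (0.37 log units; beyond the scatter) as a further modest gap. A small lowering is therefore expected, with the estimated step being a 1.7-fold lower number from compound 1 to compound 4 (0.22 log units; within the scatter) and probably no real change. Compound 4 is estimated at 1.1 mg/kg with an expected range from 0.4 mg/kg to 3 mg/kg in this assay for now.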

Compound 4, dose for half-maximal effect: 2.55 mg/kg
For compound 4 the middle estimate is 2.3-fold (0.37 log units) below the measured one; measured number inside the range.
By their numbers in this assay, from the lowest: compound 3; then compounds 2, 1 and 4 (each within the scatter of the next).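

In this assay, 2-acetylethyl in place of vinyl leaves this position without a real change (a 1.4-fold higher number from compound 1 to compound 4 (0.14 log units; within the scatter)), and the same holds for 2-acetylethyl in place of ethoxy (a 1.5-fold higher number from compound 2 to compound 4 (0.18 log units; within the scatter)). Only 2-oxopropyl in place of methoxy gives a step beyond the scatter (a 3.5-fold higher number from compound 3 to compound 4 (0.55 log units; beyond the scatter)), so this ketone chain does not keep the lower number of compound 3. Nothing available bears on the reason. Open, going by these compounds, is whether a terminal amine or carboxylic acid on this chain would move the number beyond the scatter from compound 1.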